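Para-fluoro on the phenyl ring of a thiophene acrylamide

This account rests on a few compounds, and the source may have more. Where it says the series, first, only, none or still open, it means among the compounds named here.

Measured so far:
compound 1, `C=C1CCC(c2csc(/C=C(\C)C(N)=O)c2)CC1`, in a functional assay on HeLa cells (Homo sapiens) for cytotoxicity, read by CCK-8 assay, with a stated time of 24 h (a lower number here means a stronger inhibitor, a higher number a weaker inhibitor), compound 1 gives 5010 nM
compound 2, `C/C(=C\c1cc(-c2cccnc2)co1)C(N)=O`, in this assay compound 2 gives > 50000 nM
compound 3, `C/C(=C\c1cc(-c2ccccc2)cs1)C(N)=O`, in this assay compound 3 gives 12700 nM

The value of compound 2 is a limit of this assay and not a number, namely (the limit of > 50000 nM in this assay, at which 1 of the 3 values shown sits). Among the two numbers, compound 3 stands highest; its nearest neighbour, compound 1, gives a number that is lower by a margin beyond the usual scatter of repeated measurements.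

Compound 4, `C/C(=C\c1cc(-c2ccc(F)cc2)cs1)C(N)=O`, has not yet been measured in this assay. It differs from compound 3 in one place: fluoro in place of hydrogen on an aromatic carbon. For the measured compounds named here, no step between two measured compounds matches this change, so there is no measured yardstick for it. A single fluorine replacing a hydrogen is a small change to a molecule of this size. The step from compound 3 to compound 4 is therefore expected to be small, a 1.3-fold lower number from compound 3 to compound 4 (0.10 log units; within the scatter), in no clear direction and likely within the scatter. Compound 4 is expected to give about 10000 nM in this assay, with a plausible range from 4000 nM to 30000 nM.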

Compound 4, half-maximal inhibitory concentration: 20800 nM
For compound 4 the middle estimate is 2.1-fold (0.32 log units) below the measured one, within the range that was stated.
By their numbers in this assay, from the lowest: compound 1; then compounds 3 and 4 (each within the scatter of the next). At a limit, above all of these: compound 2.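

In this assay, for the compounds shown here, fluoro in place of hydrogen on an aromatic carbon, para to a large group, gives the first step that can be read between two measured compounds here (a 1.6-fold higher number from compound 3 to compound 4 (0.21 log units; within the scatter)). This shows that, on this core, a single fluorine at this position does not shift the number by more than repeated measurements of the same compound would be expected to vary. No measurement shown here speaks to why the step has this size.

The compounds shown leave open whether a chloro group, a methoxy group, an amine or a carboxylic acid at this same position would give a step beyond the scatter. They also leave open whether fluoro elsewhere on this six-membered aromatic ring would behave in the same way.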